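The source may report more compounds than this note shows. Statements on the series, on what has been measured and on what is new or still open speak of the compounds shown alone.

Measured so far in a functional assay on RAW264.7 cells (Mus musculus) for inhibition; a higher number here means a weaker inhibitor, a lower number a stronger inhibitor:
compound 1 `O=C1/C(=C/c2ccccc2F)CCc2cc(O)ccc21` gives 1740 nM.
compound 2 `O=C1/C(=C/c2ccccc2Cl)CCc2cc(O)ccc21` gives 1910 nM.
compound 3 `O=C1/C(=C/c2cccc(F)c2)CCc2ccc(O)cc21` gives 830 nM.

Compound 1 and compound 2 share one core and differ only in chloro in place of fluoro on an aromatic carbon. That exchange produced a 1.1-fold higher number from compound 1 to compound 2 (0.04 log units; within the scatter), so these two compounds cannot be ordered against each other. Compound 3 is built from the same atoms as compound 1 joined differently; the difference between the two cores is not broken down here. Compound 3 stands lowest of the three numbers, with compound 1 above it beyond the scatter and compound 2 further still.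

Compound 4 `O=C1/C(=C/c2cccc(Cl)c2)CCc2ccc(O)cc21` has not yet been measured. It differs from compound 3 by chloro in place of fluoro on an aromatic carbon. This is the same kind of change as from compound 1 to compound 2, but not the same: there the chloro sat ortho to a large group, here it sits meta to a large group. Because a 1.1-fold higher number from compound 1 to compound 2 (0.04 log units; within the scatter) was within the scatter, compound 4 is expected to stay close to compound 3 in this assay. Compound 4 is thus expected to show a step of a 1.1-fold higher number from compound 3 to compound 4 (0.04 log units; within the scatter). Compound 4 is therefore estimated at 900 nM, most likely between 450 nM and 1800 nM.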

Compound 4, half-maximal inhibitory concentration: 210 nM
Beside the measured number, compound 4's estimate is 4.3-fold (0.63 log units) above it; measured number below the stated range.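

In this assay, putting chloro in place of fluoro on the core of compound 3 gave a 4.0-fold lower number from compound 3 to compound 4 (0.60 log units; beyond the scatter), so on this core the exchange makes a real difference to the number. The same exchange did not carry over unchanged from one core to the other: the same change on two cores in this assay, a 1.1-fold higher number (0.04 log units; within the scatter) from compound 1 to compound 2 and a 4.0-fold lower number (0.60 log units; beyond the scatter) from compound 3 to compound 4, 4.3-fold (0.64 log units) apart, beyond the scatter of two such steps. This shows that the result of this exchange on one core cannot simply be assumed for the other, but it does not show which difference between the two cores is responsible, and two pairs set no rule for any further core.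

On these data alone, it remains open whether bromo, methyl or methoxy, placed meta to a large group on the core of compound 3, would give a number like that of compound 4 or one closer to that of compound 3. As far as these compounds go, it is also open how an amine or a carboxylic acid at that place would read in this assay.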